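The source may report more compounds than this note shows. Statements on the series, on what has been measured and on what is new or still open speak of the compounds shown alone.

Compounds measured so far:
Compound 1 `CC(C)n1cnc2c(Nc3ccccc3)nc(NCOCc3ccc(C(=O)Nc4ccccc4N)cc3)nc21` gives 6.58% in a functional assay on HepG2 cells (Homo sapiens) for antiproliferative activity, read by CCK-8 assay, with a stated time of 72 h, tested at 2 uM; a higher number here means a stronger effect of the compound at the concentration tested, a lower number a weaker effect.
Compound 2 `CC(C)n1cnc2c(Nc3cccc(Cl)c3)nc(NCOCc3ccc(C(=O)Nc4ccccc4N)cc3)nc21` gives 1.48% in this assay.

Compound 2 stands lowest of the two numbers, with compound 1 nearest; the step of a number 5.1 percentage points lower from compound 1 to compound 2 (within the scatter) is within the scatter, so the two values cannot be told apart. Both compounds show only a weak effect at the tested concentration.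

Compound 3 `Nc1ccccc1NC(=O)c1ccc(COCNc2nc(Nc3cccc(Cl)c3)c3ncn(C4CCCC4)c3n2)cc1` is not yet measured. It differs from compound 2 by cyclopentyl in place of isopropyl on an aromatic nitrogen. Going by the values given here, no measured step bears on this change: the one step known, a number 5.1 percentage points lower from compound 1 to compound 2 (within the scatter), concerns the chloro in place of hydrogen on an aromatic carbon and says nothing about the substituent on the aromatic nitrogen. With nothing to go on beyond the low values of compound 1 and compound 2, the expectation is no step beyond the scatter, a number 3.5 percentage points higher from compound 2 to compound 3 (within the scatter). Compound 3 is therefore estimated at 5%, with a range from -5% to 20%.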

Compound 3, a percentage reported as inhibition, at one concentration (the size of the read-out at that concentration, not a potency): 32.6%
The estimate for compound 3 lay 27.6 percentage points below the measured number, outside the stated range (above it).
By their numbers in this assay, from the lowest: compounds 2 and 1 (each within the scatter of the next); then compound 3.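

On the aromatic nitrogen of the five-membered aromatic ring, cyclopentyl in place of isopropyl gives a number 31.1 percentage points higher from compound 2 to compound 3 (beyond the scatter) in this assay. Compounds 1 and 2 both carry isopropyl and stay within the scatter of each other, so this position is the first in the compounds shown where a single change moves the read-out beyond the scatter. Neither group has hydrogen-bond donors or acceptors, so the step comes with a gain in carbon atoms and a five-membered non-aromatic ring, and nothing at hand gives a cause for it.

From the compounds shown here alone, whether the ring or the carbon count carries the step stays open; a cyclohexyl or an open-chain pentyl group on this nitrogen would separate the two. Also open, going by these compounds, is whether cyclopentyl gives a similar step on the unsubstituted aniline of compound 1, without the chloro.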